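Furyl series: cyano replaces methoxy on the pendant phenyl

A few compounds are considered here, and "the series" means these few. Any claim that something is new, unique, unknown or untested is made for them only; others in the source may bear on it.

Of the compounds shown here, two of the shared core have numbers so far in an assay on CHO cells for displacement of a labelled ligand from adenosine receptor A3 (Homo sapiens), read by scintillation counting, with a stated time of 3 h; a lower number here means a stronger inhibitor, a higher number a weaker inhibitor. Compound 1 `N#Cc1cccc(-c2nc(N)c3nc(-c4ccccc4)sc3n2)c1` gives 247 nM. Compound 2 `COc1cccc(-c2nc(N)c3nc(-c4ccco4)sc3n2)c1` gives 4.9 nM and stands lowest of the two; the nearest number is that of compound 1, higher by a gap beyond the scatter. Compound 1 and compound 2 differ in two places, so neither change can be credited on its own.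

Compound 3 `N#Cc1cccc(-c2nc(N)c3nc(-c4ccco4)sc3n2)c1` keeps the furyl group of compound 2 and changes only the pendant phenyl: cyano in place of methoxy on an aromatic carbon. Among the measured compounds shown here, no single-change step is on hand for this exchange. A modest weakening is expected, plausibly beyond the scatter but well short of the gap between compound 1 and compound 2. The expected step in this assay is a 5.1-fold higher number from compound 2 to compound 3 (0.71 log units; beyond the scatter). Compound 3 is thus estimated at 25 nM, with a range from 5 nM to 120 nM.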

Compound 3, inhibition constant: 61.5 nM
Estimate against measurement, compound 3: 2.5-fold (0.39 log units) below; the range from low to high includes it.
By their numbers in this assay, from the lowest: compound 2; then compound 3; then compound 1.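

In this assay the exchange on the pendant phenyl now stands alone: cyano in place of methoxy, meta to a large group, gives a 13-fold higher number from compound 2 to compound 3 (1.10 log units; beyond the scatter) and so counts on its own at this position with furan-2-yl held fixed. The other change also separates out, as furan-2-yl in place of phenyl gives a 4.0-fold lower number from compound 1 to compound 3 (0.60 log units; beyond the scatter) with cyano held fixed. Both steps lie beyond the scatter, and the step on the pendant phenyl is the larger of the two.

Open, from the compounds shown here alone, is whether the methoxy-to-cyano step keeps its size with phenyl in place of furan-2-yl. Also open, going by these compounds, is how an amine, a hydroxyl or a longer chain such as ethoxy would read at this position.

No measurement on hand bears on the reason for either step.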